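A few compounds are considered here, and "the series" means these few. Any claim that something is new, unique, unknown or untested is made for them only; others in the source may bear on it.

In a functional assay on OVCAR-3 cells (Homo sapiens) for antiproliferative activity, read by MTT assay, with a stated time of 24 h (on this read-out higher numbers stand for weaker inhibition and lower numbers for stronger inhibition), compound 1 `O=C(NNc1ccccc1Cl)c1ccc(NS(=O)(=O)c2cnc(O)nc2O)cc1` gives 7230 nM. Compound 2 `Cc1ccc(C(=O)NNC(=O)c2ccc(NS(=O)(=O)c3cnc(O)nc3O)cc2)cc1` stands at > 20000 nM, which is a limit of the assay and not a number. Compound 3 `O=C(NNC(=O)c1ccccc1Cl)c1ccc(NS(=O)(=O)c2cnc(O)nc2O)cc1` has yet to be measured. It carries 2-chlorophenyl in place of 4-methylphenyl on a carbonyl carbon. For the measured compounds named here, only one measured step bears on this change: an at least 2.7-fold higher number from compound 1 to compound 2 (0.44 log units; beyond the scatter). That step also involves the 2-chlorophenyl group, but on an amine nitrogen and not on a carbonyl carbon, so it is only an indirect guide. Its direction, with the 2-chlorophenyl compound giving the lower number, suggests a modest move towards stronger inhibition in this assay, and an estimated at least 1.4-fold lower number from compound 2 to compound 3 (0.15 log units; that floor lies within the scatter) is expected. For compound 3 the expected value is 14000 nM, with an estimated range of 6000 nM to 30000 nM.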

Compound 3, half-maximal inhibitory concentration: 5220 nM
Beside the measured number, compound 3's estimate is 2.7-fold (0.43 log units) above it; measured number below the stated range.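

In this assay, the change on the carbonyl carbon now has a direct reading: 2-chlorophenyl in place of 4-methylphenyl gives an at least 3.8-fold lower number from compound 2 to compound 3 (0.58 log units; beyond the scatter) and so moves clearly towards stronger inhibition. Compound 2 is held only by a limit of the assay, so this step has a floor and no known top: the limit of > 20000 nM in this assay, at which 1 of the 3 values shown sits. The other step, free of any limit, is a 1.4-fold lower number from compound 1 to compound 3 (0.14 log units; within the scatter) and shows that the 2-chlorophenyl group gives much the same reading on a carbonyl carbon as on an amine nitrogen.

The compounds shown leave open whether the lower number follows the chlorine or its place on the ring, a question that a 4-chlorophenyl or a 2-methylphenyl group on the same carbonyl carbon would settle. They also say nothing about a plain phenyl or a pyridyl ring there.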